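A few compounds are considered here, and "the series" means these few. Any claim that something is new, unique, unknown or untested is made for them only; others in the source may bear on it.

Measured so far:
compound 1 `O=C(O)Cc1sc(C(c2ccccc2)c2ccccc2)nc1-c1ccc(F)cc1` — 80%
compound 2 `O=C(O)Cc1sc(C(c2ccccc2)c2ccc(Cl)cc2)nc1-c1ccc(F)cc1` — 80%

In an in vitro functional assay on HEK285-7 cells for antagonist activity at prostaglandin D2 receptor 2 (Homo sapiens), read by BRET and beta-arrestin recruitment (on this read-out lower numbers stand for smaller maximal responses and higher numbers for larger maximal responses), compound 1 gives 80% and stands level with compound 2, which gives 80%. Within the data shown here, the single measured step, no change at the digits printed from compound 1 to compound 2 (within the scatter), shows that a chloro in place of hydrogen on an aromatic carbon left the maximal response unchanged. Compound 3 `O=C(O)Cc1sc(C(c2ccccc2)c2ccccc2)nc1-c1cccc(F)c1` differs from compound 1 as follows: 3-fluorophenyl in place of 4-fluorophenyl on an aromatic carbon. That measured step touches a different part of the shared core, so it bears on this change only loosely, and no movement beyond the scatter is foreseen. For compound 3 the estimated value is 80%, with a range from 65% to 95%. The expected step of no change at the digits printed from compound 1 to compound 3 (within the scatter) is therefore none beyond the scatter.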

Compound 3, largest response reached (reported as efficacy), in percent of the reference or control that the assay uses: 80%
Compound 3: middle estimate and measured number agree at the digits printed, within the range that was stated.
By their numbers in this assay, from the lowest: compounds 1, 2 and 3 (each within the scatter of the next).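

In this assay, putting 3-fluorophenyl in place of 4-fluorophenyl on the aromatic carbon next to the ring nitrogen gives no change at the digits printed from compound 1 to compound 3 (within the scatter). Among these compounds, the earlier step concerned a different part of the shared core, so this is the first sign that the maximal response can hold when the fluorine changes its place on this phenyl ring. Nothing available explains this outcome. Still open, on these data alone, is whether the response would also hold with a plain phenyl here, or with a methoxy group or an amine in place of the fluorine.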